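Swapping the aryl group on a shared core: compound 4

A few compounds are considered here, and "the series" means these few. Any claim that something is new, unique, unknown or untested is made for them only; others in the source may bear on it.

Measured compounds:
- compound 1 `c1ccc2c(-c3cn4ccnc4c(-c4ccc5ncn(C6CCCCC6)c5c4)n3)cccc2c1` gives 9.08% in a functional assay on SNB-19 cells (Homo sapiens) for inhibition, read by sulforhodamine B assay, with a stated time of 48 h, tested at 10 uM; a higher number here means more inhibition at the concentration tested (going by the name of the read-out), a lower number less inhibition
- compound 2 `CC(=O)c1ccc(-c2cn3ccnc3c(-c3ccc4ncn(C5CCCCC5)c4c3)n2)cc1` gives 3.96% in this assay
- compound 3 `Brc1ccc(-c2cn3ccnc3c(-c3ccc4ncn(C5CCCCC5)c4c3)n2)cc1` gives 18.3% in this assay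

All three share one core and differ only in the aryl group attached to it. Compound 3 has the highest of the three numbers, yet one of its steps lies within the scatter, a number 9.2 percentage points higher from compound 1 to compound 3 (within the scatter), so those two compounds cannot be ordered. Only a number 14.3 percentage points higher from compound 2 to compound 3 (beyond the scatter) is beyond the scatter, and even that step is modest.

Compound 4 `COc1ccccc1-c1cn2ccnc2c(-c2ccc3ncn(C4CCCCC4)c3c2)n1` carries 2-methoxyphenyl in place of 4-bromophenyl on an aromatic carbon. Going by the values given here, no measured step involves a methoxy group, so the only guidance comes from the two steps that exchange the same aryl group: a number 9.2 percentage points higher from compound 1 to compound 3 (within the scatter) and a number 14.3 percentage points higher from compound 2 to compound 3 (beyond the scatter). Across these three aryl groups the readings stayed low and moved little, so a change of the same position is expected to stay in that narrow band, with no step beyond the scatter in this assay.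

Compound 4 is therefore expected to show about 10% in this assay, between 0% and 25%, an expected step of a number 8.3 percentage points lower from compound 3 to compound 4 (within the scatter).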

Compound 4, a percentage reported as inhibition, at one concentration (the size of the read-out at that concentration, not a potency): 11.1%
Beside the measured number, compound 4's estimate is 1.1 percentage points below it; the range from low to high includes it.
By their numbers in this assay, from the lowest: compounds 2, 1, 4 and 3 (each within the scatter of the next, the first and the last beyond it).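

In this assay, the 2-methoxyphenyl group cannot be separated from any of the three earlier aryl groups, with a number 7.2 percentage points lower from compound 3 to compound 4 (within the scatter), a number 7.1 percentage points higher from compound 2 to compound 4 (within the scatter) and a number 2 percentage points higher from compound 1 to compound 4 (within the scatter). A methoxy group at this position therefore adds no new step beyond the scatter, and among these four compounds the only such step remains a number 14.3 percentage points higher from compound 2 to compound 3 (beyond the scatter). Nothing available here explains these readings or why the 2-methoxyphenyl group fits within this narrow band.

All four groups at this position are aromatic rings without a charge, so the compounds shown leave open whether a phenyl ring carrying an amine or a carboxylic acid would give a reading outside this band. They also leave open whether a methoxy group at the 4-position of the phenyl ring would read like compound 4.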